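Swapping a benzyl substituent on an oxime ether against cancer cells

The source may hold more compounds than are shown below. What is called first, only, known or untested is meant among the compounds shown, and "the series" means these compounds.

Measured so far:
compound 1 `Clc1ccc2c(O/N=C(/C=C/c3ccc(OCc4ccccc4Cl)cc3)\C=C\c3ccccn3)ncnc2c1`: 84.7%
compound 2 `Clc1ccc(COc2ccc(/C=C/C(/C=C/c3ccccn3)=N/Oc3ncnc4ccccc34)cc2)c(Cl)c1`: 89.6%
compound 3 `Cc1cccc(COc2ccc(/C=C/C(/C=C/c3ccccn3)=N/Oc3ncnc4ccccc34)cc2)c1`: 97.5%

In a functional assay on SMMC-7721 cells (Homo sapiens) for inhibition, read by MTT assay, with a stated time of 72 h, tested at 10 uM (on this read-out higher numbers stand for a stronger effect at the one concentration tested and lower numbers for a weaker effect), compound 3 gives 97.5%, the highest of the three numbers; compound 2 sits a number 7.9 percentage points higher from compound 2 to compound 3 (within the scatter) below it, and compound 1 lies further away, beyond the scatter.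

Compound 4 `Clc1ccccc1COc1ccc(/C=C/C(/C=C/c2ccccn2)=N/Oc2ncnc3ccccc23)cc1` has not yet been measured. It differs from compound 3 by 2-chlorophenyl in place of 3-methylphenyl on a saturated chain carbon bound to an oxygen on an aromatic ring. Among the measured compounds shown here, only one measured step touches this position: the change from compound 2 to compound 3, which moved the read-out by a number 7.9 percentage points higher from compound 2 to compound 3 (within the scatter), within the scatter. For the measured compounds named here, the same 2-chlorobenzyl group as in compound 4 appears on a different core in compound 1, so no counted step is available there, only a value: compound 1 gives 84.7%, which is lower than that of compound 3.

Taken together, these numbers suggest that exchanging 3-methylbenzyl for 2-chlorobenzyl is unlikely to move the read-out by more than the usual scatter, with a slight lean downward. Compound 4 is therefore expected to come in at 88%, between 76% and 97%, which would mean a step of a number 9.5 percentage points lower from compound 3 to compound 4 (within the scatter) in this assay.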

Compound 4, a percentage reported as inhibition, at one concentration (the size of the read-out at that concentration, not a potency): 96.9%
Compound 4: the middle estimate sits 8.9 percentage points below what was measured; the range from low to high includes it.
By their numbers in this assay, from the lowest: compounds 1, 2, 4 and 3 (each within the scatter of the next, the first and the last beyond it).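

In this assay, 2-chlorobenzyl and 3-methylbenzyl cannot be told apart, with a number 0.6 percentage points lower from compound 3 to compound 4 (within the scatter), and hydrogen in place of chloro on an aromatic carbon of the benzyl group gives a number 7.3 percentage points higher from compound 2 to compound 4 (within the scatter), so compounds 2, 3 and 4 show that this position accepts a chloro, two chloros or a methyl on the benzyl ring with no difference beyond the scatter. Among the compounds shown here, the one step beyond the scatter involving compound 4 comes from the core instead: with the 2-chlorobenzyl group unchanged, hydrogen in place of chloro on an aromatic carbon of the core gives a number 12.2 percentage points higher from compound 1 to compound 4 (beyond the scatter), a modest step that makes the core a more responsive place than the benzyl ring in this small set. No measurement here offers an explanation for either finding.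

The compounds shown leave open whether a benzyl ring carrying an amine or a carboxylic acid, or a longer chain in place of the benzyl group, would keep the read-out at this level. Because each compound was read at one concentration, these numbers also leave open how the potencies of compound 2, compound 3 and compound 4 compare.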